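The source may hold more compounds than are shown below. What is called first, only, known or untested is meant among the compounds shown, and "the series" means these compounds.

Compound 2 `COc1ccc(-c2csc(N)c2C(=O)OCc2cccc(C#N)c2)cc1OC` and compound 1 `COc1ccc(-c2csc(N)c2C(=O)OCc2cccc(C)c2)cc1OC` share one core and differ only at a single aromatic carbon. In an assay on isolated protein for inhibition of protein kinase C zeta type (Homo sapiens), with stated times of 1 h and 2.5 min, tested at 30 uM (on this read-out higher numbers stand for more inhibition at the one concentration tested (going by the name of the read-out) and lower numbers for less inhibition), compound 2 gives 70%, and compound 1 gives 67%. Among the measured compounds shown here, of the two numbers the one for compound 2 is nominally the higher, but the step of a number 3 percentage points higher from compound 1 to compound 2 (within the scatter) lies within the scatter, so neither compound can be set above the other on this read-out. Compound 3 `COc1ccc(-c2csc(N)c2C(=O)OCc2ccncc2)cc1OC` is not yet measured. It differs from compound 2 by pyridin-4-yl in place of 3-cyanophenyl on a saturated chain carbon bound to an oxygen next to a carbonyl group. For the measured compounds named here, the only measured step concerns a substituent on an aromatic ring, whereas the change toward compound 3 exchanges the ring itself, so no measured step matches it in kind. What the two numbers do show is that a change in this region of the molecule left this assay unmoved beyond the scatter. Going by the values given here, on that basis the expected step of a number 8 percentage points lower from compound 2 to compound 3 (within the scatter) is none beyond the scatter, with a wide range; no closer precedent exists. Compound 3 is therefore estimated at 62% in this assay, between 38% and 82%.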

Compound 3, a percentage reported as inhibition, at one concentration (the size of the read-out at that concentration, not a potency): 53%
Compound 3: the middle estimate sits 9 percentage points above what was measured; measured number inside the range.
By their numbers in this assay, from the lowest: compound 3; then compounds 1 and 2 (each within the scatter of the next).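

The place on a saturated chain carbon bound to an oxygen next to a carbonyl group is not indifferent to change in this assay: pyridin-4-yl in place of 3-cyanophenyl gives a number 17 percentage points lower from compound 2 to compound 3 (beyond the scatter) on this read-out. Pyridin-4-yl in place of 3-methylphenyl gives a number 14 percentage points lower from compound 1 to compound 3 (beyond the scatter) in the same assay, so the result holds against both earlier compounds, and the size of both steps is modest. Whereas cyano in place of methyl on the aromatic ring left the reading within the scatter, exchanging the ring itself moved it beyond the scatter, and nothing measured here explains this.

The compounds shown cannot separate the effect of the ring nitrogen from the loss of the nitrile or methyl substituent, since both differences come together in compound 3. They also leave open how a plain benzyl group, a pyridin-3-yl ring or a longer chain carrying the ring would read at this place, and whether any replacement here could give a higher number than the 3-cyanobenzyl and 3-methylbenzyl groups do.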